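This account rests on a few compounds, and the source may have more. Where it says the series, first, only, none or still open, it means among the compounds named here.

Within the data shown here, compound 2, `Nc1scc(CN2CCN(c3ccc(F)cc3F)CC2)c1C(=O)c1ccc(Cl)cc1`, stands at 1% in an assay on CHO cells for displacement of a labelled ligand from adenosine receptor A1 (Homo sapiens), read by scintillation counting, with a stated time of 120 min, tested at 10 uM (on this read-out lower numbers stand for less inhibition and higher numbers for more inhibition at the one concentration tested (going by the name of the read-out)), the higher of the two numbers measured so far, although compound 1, `Nc1scc(CN2CCN(C3CCCCCC3)CC2)c1C(=O)c1ccc(Cl)cc1`, sits within the scatter of it with 0%. Among the measured compounds shown here, the one step measured between them, a number 1 percentage points higher from compound 1 to compound 2 (within the scatter), shows that exchanging a cycloheptyl group for a 2,4-difluorophenyl group on the ring amine nitrogen left the read-out essentially unchanged at this single concentration.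

Compound 3, `Nc1scc(CN2CCN(c3cc(F)cc(F)c3)CC2)c1C(=O)c1ccc(Cl)cc1`, is built from the same atoms as compound 2 but joined differently: 3,5-difluorophenyl in place of 2,4-difluorophenyl on an amine nitrogen in a ring. For the measured compounds named here, no measured step speaks to moving the two fluorine atoms about the aromatic ring, so the only guidance is the step from compound 1 to compound 2, which was within the scatter. With both measured compounds near zero inhibition, the step for compound 3 is therefore expected to be a number 1 percentage points higher from compound 2 to compound 3 (within the scatter), that is, no change beyond the scatter in this assay. Compound 3 is estimated to give 2%, with a range from -8% to 12%.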

Compound 3, a percentage reported as inhibition, at one concentration (the size of the read-out at that concentration, not a potency): 0%
Estimate against measurement, compound 3: 2 percentage points above, within the range that was stated.
By their numbers in this assay, from the lowest: compounds 1, 3 and 2 (each within the scatter of the next).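

In this assay, moving the two fluorine atoms around the aromatic ring gives a number 1 percentage points lower from compound 2 to compound 3 (within the scatter), so 3,5-difluorophenyl and 2,4-difluorophenyl on the amine nitrogen in a ring cannot be told apart at this one concentration. Setting 3,5-difluorophenyl in place of cycloheptyl gives no change at the digits printed from compound 1 to compound 3 (within the scatter), which extends the picture from the first step: cycloheptyl and both difluorophenyl groups now lie within the scatter of one another at this position, and all of them sit near zero on this read-out. Nothing measured alongside these compounds offers an explanation for this flat result.

Since all three numbers lie so close together, the compounds shown do not reveal whether any group on that ring nitrogen, such as a benzyl group, a pyridyl ring or a chain ending in a carboxylic acid, would move the read-out beyond the scatter. Also open, on these data alone, is whether a change elsewhere on the shared core, such as an amide in place of the free amine or a methoxy group in place of the chlorine, would do so.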